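The source may hold more compounds than are shown below. What is called first, only, known or untested is meant among the compounds shown, and "the series" means these compounds.

Measured compounds and their values in an assay for displacement of a labelled ligand from corticotropin-releasing factor receptor 1 (Homo sapiens); on this read-out lower numbers stand for stronger inhibition and higher numbers for weaker inhibition:
compound 1, `CCCN(CC1CC1)C(=O)c1sc(Nc2c(Cl)cc(Cl)cc2Cl)nc1C(F)(F)F`, gives 31000 nM;
compound 2, `CCCN(Cc1sc(Nc2c(C)cc(Cl)cc2Cl)nc1C(F)(F)F)CC1CC1`, gives 16 nM;
compound 3, `CCCN(Cc1sc(Nc2c(C)cc(C)cc2Cl)nc1C(F)(F)F)CC1CC1`, gives 23 nM.

Compound 3 stands second highest of the three numbers in this assay. Its nearest neighbour is compound 2, the gap within the scatter; the furthest is compound 1, the gap beyond the scatter. Compound 4, `CCCN(Cc1sc(Nc2c(C)cc(Cl)cc2C)nc1C(F)(F)F)CC1CC1`, differs from compound 3 in one place: 4-chloro-2,6-dimethylphenyl in place of 2-chloro-4,6-dimethylphenyl on a nitrogen on an aromatic ring. Within the data shown here, the only measured step that bears on a change of the aryl substituents is a 1.4-fold higher number from compound 2 to compound 3 (0.16 log units; within the scatter), a methyl in place of a chloro on an aromatic carbon, which stayed within the scatter. Among the measured compounds shown here, the step to compound 4 keeps the same atoms and only rearranges them, and no measured pair tests such a rearrangement directly; the one substituent step did not move the number beyond the scatter. The expected step of a 1.3-fold higher number from compound 3 to compound 4 (0.12 log units; within the scatter) is therefore none beyond the scatter, with no direction claimed. Compound 4 is expected at 30 nM, in the range 10 nM to 100 nM.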

Compound 4, inhibition constant: 73 nM
Compound 4: middle estimate off by 2.4-fold (0.39 log units), on the low side; the range from low to high includes it.
By their numbers in this assay, from the lowest: compounds 2 and 3 (each within the scatter of the next); then compound 4; then compound 1.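

In this assay, rearranging the same atoms within the aryl group on a nitrogen on an aromatic ring has a measurable result: 4-chloro-2,6-dimethylphenyl in place of 2-chloro-4,6-dimethylphenyl gives a modest loss (from a 3.2-fold higher number from compound 3 to compound 4 (0.50 log units; beyond the scatter)), so the number depends on where chloro and methyl stand and not only on which of them are present. Methyl in place of chloro therefore cannot be read as a neutral exchange across this group: one such exchange gives a step beyond the scatter (from a 4.6-fold higher number from compound 2 to compound 4 (0.66 log units; beyond the scatter)), whereas the exchange of the other chloro stays within it (from a 1.4-fold higher number from compound 2 to compound 3 (0.16 log units; within the scatter)). Nothing available explains this difference.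

From the compounds shown here alone, whether methoxy or bromo would be tolerated in these places remains open, as does the outcome with a third methyl in place of the remaining chloro. The compounds shown also leave open whether a butyl chain on the side-chain amine would change the picture.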